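The compounds below may be only part of what the source reports. "The series", "measured", "known", "first", "only" and "open" are said of these compounds alone.

Series notes. In a functional assay on HEK293 cells for agonist activity at Free fatty acid receptor 1 (Homo sapiens), read by fluorescence and calcium flux, with a stated time of 10 min (a higher number here means a larger maximal response, a lower number a smaller maximal response), compound 1 `O=C(O)CCc1ccc(OCC2COc3cc(Br)ccc3O2)cc1F` gives 67%, compound 2 `O=C(O)CCc1ccc(NCC2COc3ccc(Cl)cc3O2)cc1F` gives 69%, and compound 3 `O=C(O)CC(c1ccc(OCC2COc3ccc(Cl)cc3O2)cc1)c1cnco1` gives 63%. Compound 3 stands at the bottom of these three numbers, yet its gap to compound 1 and its gap to compound 2 both lie within the usual scatter, so the three compounds are not separated from one another. Among the measured compounds shown here, no pair among them differs in only one place, so no single-change step is known from the measured set. Compound 4 `O=C(O)CC(c1ccc(F)cc1)c1ccc(OCC2COc3ccc(Cl)cc3O2)cc1` differs from compound 3 by 4-fluorophenyl in place of 1,3-oxazol-5-yl on a saturated chain carbon bound to an aromatic carbon and a saturated chain carbon. For the measured compounds named here, no measured pair here speaks to this change, so in this assay the expected step of a number 3 percentage points higher from compound 3 to compound 4 (within the scatter) is estimated as none beyond the scatter, in either direction. Compound 4 is expected to give about 66%, with a range from 50% to 82%.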

Compound 4, largest response reached (Emax), in percent of the reference or control that the assay uses: 83%
For compound 4 the middle estimate is 17 percentage points below the measured one; measured number outside the range, above it.
By their numbers in this assay, from the lowest: compounds 3, 1 and 2 (each within the scatter of the next); then compound 4.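

Among the compounds shown here, at the saturated chain carbon bound to an aromatic carbon and a saturated chain carbon, 4-fluorophenyl in place of 1,3-oxazol-5-yl gives in this assay a number 20 percentage points higher from compound 3 to compound 4 (beyond the scatter) as the only single-place step. The earlier compounds shown here could not show that the maximal response depends on the group at this carbon. Nothing at hand gives a reason for this step.

As far as these compounds go, whether the rise follows from the fluorine or from the six-membered carbon ring stays open. An unsubstituted phenyl or a pyridine ring at this carbon would separate the two.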